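A few compounds are considered here, and "the series" means these few. Any claim that something is new, unique, unknown or untested is made for them only; others in the source may bear on it.

Compound 3 `CCCCCCCCCCCCOC(=O)CCC(=O)N1CCN(CCCOc2cc3c(Nc4ccc(F)c(Cl)c4)ncnc3cc2OC)CC1` gives, in a functional assay on A549 cells (Homo sapiens) for cytotoxicity, read by MTT assay, with a stated time of 24 h, tested at 60 uM (on this read-out higher numbers stand for a weaker effect at the one concentration tested and lower numbers for a stronger effect), a value of 2%, the lowest of the three measured numbers. Compound 1 `CCOC(=O)CCC(=O)N1CCN(CCCOc2cc3c(Nc4ccc(F)c(Cl)c4)ncnc3cc2OC)CC1` gives 61.6% in this assay, and compound 2 `CCCOC(=O)CCC(=O)N1CCN(CCCOc2cc3c(Nc4ccc(F)c(Cl)c4)ncnc3cc2OC)CC1` gives 70.4%. The chain-lengthening steps are large: a number 59.6 percentage points lower from compound 1 to compound 3 (beyond the scatter) and a number 68.4 percentage points lower from compound 2 to compound 3 (beyond the scatter). Compound 4 `CCCCCCCCCCCCCOC(=O)CCC(=O)N1CCN(CCCOc2cc3c(Nc4ccc(F)c(Cl)c4)ncnc3cc2OC)CC1` differs from compound 3 by methyl in place of hydrogen on a saturated chain carbon, ten or more bonds along the chain from an oxygen next to a carbonyl group. The closest measured analogue of this change is the one-carbon extension from compound 1 to compound 2, where a number 8.8 percentage points higher from compound 1 to compound 2 (within the scatter). The drops to compound 3 came from a decyl or a nonyl entering in place of hydrogen, not a methyl. A single added carbon at the end of an already long chain is therefore expected to move the value little, and compound 3 already sits near the floor of the scale. Compound 4 is therefore expected to show a number 2 percentage points higher from compound 3 to compound 4 (within the scatter), staying within the scatter. The estimate for compound 4 in this assay is 4%, with a range from 0% to 20%.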

Compound 4, a percentage reported as activity, at one concentration (the size of the read-out at that concentration, not a potency): 20.6%
The estimate for compound 4 lay 16.6 percentage points below the measured number; the measured number lies above the stated range.
By their numbers in this assay, from the lowest: compound 3; then compound 4; then compounds 1 and 2 (each within the scatter of the next).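

At the far end of the long chain, a methyl in place of hydrogen still registers in this assay, with a number 18.6 percentage points higher from compound 3 to compound 4 (beyond the scatter), so the longer of these two chains does not end in a flat floor. The effect nevertheless stays much stronger than with the shorter chains, with a number 49.8 percentage points lower from compound 2 to compound 4 (beyond the scatter) and a number 41 percentage points lower from compound 1 to compound 4 (beyond the scatter), although compound 4, which has the longest chain here, goes against any simple rule that a longer chain always gives a lower number. The methyl step on the long chain cannot be separated from the same step on the short chain: the same change on two cores in this assay, a number 8.8 percentage points higher (within the scatter) from compound 1 to compound 2 and a number 18.6 percentage points higher (beyond the scatter) from compound 3 to compound 4, 9.8 percentage points apart, within the scatter of two such steps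

The compounds shown leave open how the number moves across the wide gap in chain length between compound 2 and compound 3, and whether a still longer chain would raise it further. They also leave open what a carboxylic acid or an amine at the chain end would do.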